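The source may report more compounds than this note shows. Statements on the series, on what has been measured and on what is new or still open speak of the compounds shown alone.

In an assay (strain Wistar) for binding affinity to Neuronal acetylcholine receptor; alpha4/beta2 (Rattus norvegicus) (on this read-out lower numbers stand for stronger inhibition and higher numbers for weaker inhibition), the three measured compounds stand as follows:
compound 1, `Clc1ncc(N2CCCNCC2)cc1Br`: 1.4 nM
compound 2, `c1cncc(N2CCCNCCC2)c1`: 0.9 nM
compound 3, `Brc1ccc(N2CCCNCCC2)cn1`: 0.45 nM

Compound 3 gives the lowest of the three numbers. Compound 2 is nearest to it, and the difference between the two lies within the scatter, so the two cannot be ranked against each other. Compound 1 is the furthest, and its gap from compound 3 lies beyond the scatter.

Compound 4, `C=COc1cc(N2CCCNCCC2)cnc1Br`, has not yet been measured. It differs from compound 3 in one place: vinyloxy in place of hydrogen on an aromatic carbon. Among the measured compounds shown here, only one measured step bears on this kind of change, the addition of a ring substituent to the shared core: the step of a 2.0-fold lower number from compound 2 to compound 3 (0.30 log units; within the scatter). For the measured compounds named here, no measured step concerns a vinyloxy group or any substituent ortho to a bromo group, so the bearing is indirect. On this basis no step beyond the scatter is expected in this assay from compound 3 to compound 4, and the estimated step is a 1.6-fold higher number from compound 3 to compound 4 (0.19 log units; within the scatter). The expected value for compound 4 is therefore 0.7 nM, with a range from 0.2 nM to 2.5 nM.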

Compound 4, half-maximal inhibitory concentration: 0.38 nM
Beside the measured number, compound 4's estimate is 1.8-fold (0.27 log units) above it; the range from low to high includes it.
By their numbers in this assay, from the lowest: compounds 4, 3, 2 and 1 (each within the scatter of the next, the first and the last beyond it).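

In this assay the change of vinyloxy in place of hydrogen on an aromatic carbon, ortho to a bromo group and two atoms from the ring nitrogen, comes out as a 1.2-fold lower number from compound 3 to compound 4 (0.07 log units; within the scatter) and so cannot be told apart from no change at all. Among the compounds shown here, this is the first view of this position: the only earlier step placed a bromo group on a different ring carbon, and it now appears that a group of 3 heavy atoms, with an oxygen and a double bond outside the aromatic ring, can stand here without a step beyond the scatter. Nothing available gives a reason for this result.

From the compounds shown here alone, whether this position would read the same with an amine, a carboxylic acid or a longer alkoxy chain remains open, as does whether its double bond matters, which an ethoxy group in place of vinyloxy would test. Going by these compounds, it is also open whether the same substitution would give a similar step without the neighbouring bromo group, with hydrogen or chloro in its place.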